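The source may hold more compounds than are shown below. What is called first, only, known or untested is meant among the compounds shown, and "the series" means these compounds.

Measured in a physicochemical assay for metabolic stability, read by HPLC, with a stated time of 48 h, tested at 500 uM; a higher number here means that more of the compound is left, a lower number that less of the compound is left:
- compound 1 `c1ccc(/N=N/c2ccc(N3CCN([C@H]4CC[C@@H](c5ccccc5)CC4)CC3)cn2)cc1`: 100%
- compound 2 `c1ccc(/N=N/c2ccc(N3CCN([C@H]4CC[C@@H](c5ccccc5)CC4)CC3)cc2)cc1`: 93%

Compound 2 stands at 93%, within the scatter of compound 1. Compound 3 `c1ccc([C@H]2CC[C@@H](N3CCN(c4ccc(/N=N/c5cccnc5)cc4)CC3)CC2)cc1` is not yet measured. It departs from compound 2 as follows: pyridin-3-yl in place of phenyl on a double-bonded nitrogen. Going by the values given here, no measured step shows this change, so the expectation rests only on compound 2 at 93%. The expected step of a number 1 percentage points lower from compound 2 to compound 3 (within the scatter) in this assay is none beyond the scatter. For compound 3 the estimated value is 92%, with an expected range of 80% to 100%.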

Compound 3, percent of the compound remaining: 100%
Estimate against measurement, compound 3: 8 percentage points below; measured number inside the range.
By their numbers in this assay, from the lowest: compounds 2, 1 and 3 (each within the scatter of the next).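

Going by these compounds alone, on the double-bonded nitrogen, pyridin-3-yl in place of phenyl is the only one-place change at hand, and in this assay it gives a number 7 percentage points higher from compound 2 to compound 3 (within the scatter). This position therefore accepts a ring nitrogen and one hydrogen-bond acceptor with no step beyond the scatter. Nothing at hand bears on a cause for this result.

Open, on these data alone, is whether pyridin-4-yl, or an amine or a carboxylic acid on this ring, would also stay within the scatter. Also open, as far as these compounds go, is whether the same change on the core of compound 1 gives a similar step.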